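A few compounds are considered here, and "the series" means these few. Any claim that something is new, unique, unknown or untested is made for them only; others in the source may bear on it.

Compound 2 `CC1(C)Oc2ccc(S(=O)(=O)N3CCCCC3)cc2[C@@H](/N=C(\NC#N)Nc2ccc(Cl)cc2)[C@@H]1O` and compound 1 `CC1(C)Oc2ccc(C#N)cc2[C@@H](/N=C(\NC#N)Nc2ccc(Cl)cc2)[C@@H]1O` share one core and differ only in the group on an aromatic carbon. In a functional assay (aorta) with Rattus norvegicus as the target (on this read-out higher numbers stand for weaker inhibition and lower numbers for stronger inhibition), compound 1 gives 1800 nM, and in this assay compound 2 gives 1900 nM; the two numbers lie within the usual scatter of each other, as the step of a 1.1-fold higher number from compound 1 to compound 2 (0.02 log units; within the scatter) shows. Compound 3 `CC1(C)Oc2ccc(S(=O)(=O)N3CCCC4CCCCC43)cc2[C@@H](/N=C(\NC#N)Nc2ccc(Cl)cc2)[C@@H]1O` takes the next step from compound 2: a group of 10 heavy atoms (9 carbon, 1 nitrogen; one six-membered non-aromatic ring of carbon only, one six-membered non-aromatic ring with 1 hetero atom) in place of a group of 6 heavy atoms (5 carbon, 1 nitrogen; one six-membered non-aromatic ring with 1 hetero atom), on a sulfonyl sulfur. For the measured compounds named here, no measured step touches this sulfonyl group itself, so the only guide is that swapping cyano for the piperidinylsulfonyl group left the number essentially unchanged. Enlarging that group by a further fused carbon ring is therefore expected to give at most a small step, no change at the digits printed from compound 2 to compound 3 (within the scatter), in no firm direction. Compound 3 is estimated at 1900 nM, within a range from 700 nM to 5000 nM.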

Compound 3, half-maximal inhibitory concentration: 8800 nM
Estimate against measurement, compound 3: 4.6-fold (0.67 log units) below; the whole stated range lies below it.
By their numbers in this assay, from the lowest: compounds 1 and 2 (each within the scatter of the next); then compound 3.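

In this assay, the group on the sulfonyl sulfur proves able to shift the read-out: a 4.6-fold higher number from compound 2 to compound 3 (0.67 log units; beyond the scatter), a change beyond the scatter that means weaker inhibition. The earlier swap, a 1.1-fold higher number from compound 1 to compound 2 (0.02 log units; within the scatter), could not show this, as it stayed within the scatter and involved a different kind of change, on an aromatic carbon. Here, adding a carbon-only ring to the piperidin-1-yl group gives a clear difference, but nothing available accounts for it.

From the compounds shown here alone, whether the fused ring itself matters, or simply the extra carbon atoms, remains open; a dimethylamino group or an open-chain dibutylamino group on the same sulfur would help separate these possibilities. Going by these compounds, with one enlarged group in a single assay, it also remains open how far this step applies to other groups at this position.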